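The source may report more compounds than this note shows. Statements on the series, on what has been measured and on what is new or still open speak of the compounds shown alone.

Compound 1, `CCc1cccc(CC)c1NC(=O)/N=C1\CCCN1C`: in a functional assay on the whole organism with Rattus norvegicus as the target, with a stated time of 5 days (a lower number here means that less compound is needed, a higher number that more compound is needed for the effect), it is reported only as a limit of the assay, > 25 mg/kg.
Compound 2, `CN1CCC/C1=N\C(=O)Nc1cccc(Cl)c1`: in this assay compound 2 gives 15 mg/kg.
Compound 3, `CN1CCC/C1=N\C(=O)Nc1c(Cl)cccc1Cl`: for compound 3 the assay again reports only a limit, > 25 mg/kg.

Three compounds share the same core, and they differ only in what sits on the aromatic ring. Among the values shown, compound 2 stands alone as the only real number; the other two are limits, a point summed up by the limit of > 25 mg/kg in this assay, at which 2 of the 3 values shown sit. So there is no measured step between any two compounds here that could show how a change on the ring moves the minimum effective dose.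

Compound 4, `COc1cccc(NC(=O)/N=C2\CCCN2C)c1`, has not yet been tested in this assay. It differs from compound 2 in one place: methoxy in place of chloro on an aromatic carbon. Among the compounds with values here, with no measured step available, the size of this change can only be guessed. A small group exchanged for another small group on the same position is expected to move the minimum effective dose by no more than a modest step, with the direction open, and a result that falls within the scatter of compound 2 would not be surprising. The step from compound 2 to compound 4 is therefore estimated as a 1.3-fold higher number from compound 2 to compound 4 (0.12 log units; within the scatter). For compound 4 the expected minimum effective dose is 20 mg/kg, with a plausible range from 7 mg/kg to 60 mg/kg.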

Compound 4, minimum effective dose: > 25 mg/kg
Compound 4: only a limit was reported; the forecaster's own chance of this, stated with the estimate: 40%; middle value at least 1.2-fold (0.09 log units) away from the limit.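

Methoxy in place of chloro on an aromatic carbon, meta to a large group, is the first change in one place that can be read in this series, and it comes out as an at least 1.6-fold higher number from compound 2 to compound 4 (0.22 log units; that floor lies within the scatter). That figure is only a floor, so the true step could be larger, but the floor alone does not show that this exchange does more than ordinary variation between repeat measurements would. Compound 2 remains the only compound with a real number, and the set now sits mostly at a single limit of the assay: the limit of > 25 mg/kg in this assay, at which 3 of the 4 values shown sit.

On these data alone, how far the true dose of compound 4 lies past its limit stays open, and so does the size of the real step. Also open, as far as these compounds go, is whether any other group at this position, such as a methyl, a fluoro or an amine, would give a real number close to that of compound 2 or one that needs less compound than compound 2 does.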